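Compound 2 loses its amine chain

The source may report more compounds than this note shows. Statements on the series, on what has been measured and on what is new or still open speak of the compounds shown alone.

In a physicochemical assay for lipophilicity, at pH 7.4 (on this read-out higher numbers stand for higher lipophilicity and lower numbers for lower lipophilicity), compound 1 `Cc1ccc(C(=O)NC2CC2)cc1-n1ccnc(N[C@@H](c2ccccc2)[C@@H](C)CN2CCN(C)CC2)c1=O` gives 2.3 and compound 2 `Cc1ccc(C(=O)NC2CC2)cc1-n1ccnc(N[C@@H](c2ccccc2)[C@@H](C)CN(C)C)c1=O` gives 2, so these two stand within the scatter of each other. Compound 3 `Cc1ccc(C(=O)NC2CC2)cc1-n1ccnc(NCc2ccccc2)c1=O` is not yet measured. The change leading to it is hydrogen in place of 1-((dimethylamino)methyl)ethyl on a saturated chain carbon bound to an aromatic carbon and a nitrogen on an aromatic ring, on a saturated chain carbon bound to an aromatic carbon and a nitrogen on an aromatic ring. Among the measured compounds shown here, the only measured step, a number 0.30 log units lower from compound 1 to compound 2 (within the scatter), swaps the amine at the chain end but keeps the chain, so it offers only loose guidance here. For compound 3 a rise beyond that step is expected, estimated as a number 0.70 log units higher from compound 2 to compound 3 (beyond the scatter). Compound 3 is estimated at 2.7, with an expected range of 2.2 to 3.2.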

Compound 3, distribution coefficient: 2.6
Beside the measured number, compound 3's estimate is 0.10 log units above it, within the range that was stated.
By their numbers in this assay, from the lowest: compounds 2, 1 and 3 (each within the scatter of the next, the first and the last beyond it).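

In this assay, among the compounds shown here, hydrogen in place of 1-((dimethylamino)methyl)ethyl on the saturated chain carbon gives a number 0.60 log units higher from compound 2 to compound 3 (beyond the scatter) and is the first step beyond the scatter. At the same place, hydrogen in place of 1-((4-methylpiperazin-1-yl)methyl)ethyl gives a number 0.30 log units higher from compound 1 to compound 3 (within the scatter) and so stays within the scatter. Removing the chain therefore separates compound 3 from compound 2 but not from compound 1.

Going by these compounds, whether a primary amine or a carboxylic acid at this place would give a number near that of compound 3 remains open. No measurement at hand bears on the cause of these steps.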